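Replacing the 3,4-dichlorophenoxy Group of Compound 1

The compounds below may be only part of what the source reports. "The series", "measured", "known", "first", "only" and "open" are said of these compounds alone.

Measured so far:
compound 1 `Nc1cc(N)c2nc(-c3ccccc3)c(Oc3ccc(Cl)c(Cl)c3)nc2c1`: 24000 nM
compound 2 `Nc1cc(N)c2nc(-c3ccccc3)c(NCc3ccc(Cl)c(Cl)c3)nc2c1`: 18600 nM
compound 3 `CCOC(=O)[C@H](CCC(=O)O)NC(=O)c1ccc(Sc2nc3cc(N)cc(N)c3nc2-c2ccccc2)cc1`: 17800 nM

Of the compounds shown here, three sharing the core of compound 1 have been tested in a functional assay on SK-OV-3 cells (Homo sapiens) for inhibition, read by sulforhodamine B assay, with a stated time of 48 h; on this read-out higher numbers stand for weaker inhibition of growth and lower numbers for stronger inhibition of growth. In this assay compound 1 gives 24000 nM, the highest of the three numbers, but compound 2 and compound 3 both lie within the scatter of it, so no order among them can be claimed. Compound 4 `Nc1cc(N)c2nc(-c3ccccc3)c(Sc3ccc(F)cc3)nc2c1` is compound 1 with one change: (4-fluorophenyl)sulfanyl in place of 3,4-dichlorophenoxy on an aromatic carbon. Among the measured compounds shown here, no measured pair shows this change on its own, and since all three numbers sit close together, the step is expected to be none beyond the scatter. Compound 4 is therefore estimated at 20000 nM, with a range of 8000 nM to 50000 nM. That estimate means an expected step of a 1.2-fold lower number from compound 1 to compound 4 (0.08 log units; within the scatter).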

Compound 4, concentration for 50% growth inhibition: 15800 nM
Compound 4: middle estimate off by 1.3-fold (0.10 log units), on the high side, within the range that was stated.
By their numbers in this assay, from the lowest: compounds 4, 3, 2 and 1 (each within the scatter of the next).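

In this assay, (4-fluorophenyl)sulfanyl in place of 3,4-dichlorophenoxy gives a 1.5-fold lower number from compound 1 to compound 4 (0.18 log units; within the scatter). Among the compounds shown here, this is the first direct comparison at this position, and the two groups cannot be told apart here, even though the linking oxygen becomes sulfur and the two chlorines give way to one fluorine. No measurement is available to explain this result.

Going by these compounds, the swap alters the link and the ring substituents together, so their separate contributions remain unknown. On these data alone, it also remains open whether a simple amine or a carboxylic acid at this position would give a step beyond the scatter.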